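Solubility notes: trifluoromethyl for bromo on compound 3

The source may hold more compounds than are shown below. What is called first, only, known or untested is meant among the compounds shown, and "the series" means these compounds.

Compound 3 `CNC(=O)c1cc(Oc2ccc3nc(Nc4cccc(Br)c4)ncc3c2)ccn1` in a physicochemical assay for solubility, at pH 7 (a higher number here means a more soluble compound, a lower number a less soluble compound), gives < 1000 nM, which is a limit of the assay rather than a number. Compound 1 `CNC(=O)c1cc(Oc2ccc3nc(Nc4ccccc4)ncc3c2)ccn1` in this assay gives < 1000 nM, likewise a limit. Compound 2 `CNC(=O)c1cc(Oc2ccc3nc(Nc4cccc(C(C)(C)C)c4)ncc3c2)ccn1` in this assay gives < 1000 nM, again a limit. All three values thus sit at the limit of < 1000 nM in this assay, at which 3 of the 3 values shown sit. The measured steps a step that the two limits leave unreadable from compound 1 to compound 2, a step that the two limits leave unreadable from compound 1 to compound 3 and a step that the two limits leave unreadable from compound 2 to compound 3 cannot be sized because of the limit of < 1000 nM in this assay, at which 3 of the 3 values shown sit. Compound 4 `CNC(=O)c1cc(Oc2ccc3nc(Nc4cccc(C(F)(F)F)c4)ncc3c2)ccn1` differs from compound 3 by trifluoromethyl in place of bromo on an aromatic carbon. Within the data shown here, no measured step bears readably on this change, so no shift beyond the scatter is expected for a step that the limit leaves unreadable from compound 3 to compound 4, and a further limit is likely. Compound 4 is estimated at 500 nM in this assay, with a range of 100 nM to 2000 nM.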

Compound 4, solubility: < 1000 nM
Compound 4 gave a limit, no number (the forecaster's own chance of this, stated with the estimate: 75%); the middle value is on the limit's open side.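

The steps from compound 4 to compounds 1, 2 and 3 cannot be read, because all four compounds give a limit rather than a number in this assay: the limit of < 1000 nM in this assay, at which 4 of the 4 values shown sit.

The compounds shown leave open whether these four differ at all in this assay.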